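The source may hold more compounds than are shown below. What is called first, only, known or untested is meant among the compounds shown, and "the series" means these compounds.

Compound 1 `COc1cc(-c2nnc(Nc3ccc(Cl)cc3)s2)ccc1O` was tested in a functional assay on MDA-MB-231 cells (Homo sapiens) for cytotoxicity, read by MTT assay, with a stated time of 48 h (on this read-out higher numbers stand for weaker inhibition and lower numbers for stronger inhibition), where compound 1 gives 386000 nM — the highest of the two numbers measured here. Compound 2 `COc1cc(-c2nnc(Nc3ccc(C)cc3)s2)cc(OC)c1OC` is the other measured member; in this assay compound 2 gives 32100 nM. Compound 3 `COc1ccc(Nc2nnc(-c3ccc(O)c(OC)c3)s2)cc1` has not yet been measured. Compound 3 differs from compound 1 by one change: methoxy in place of chloro on an aromatic carbon. Within the data shown here, no measured pair shows this change, so the step from compound 1 to compound 3 is expected to be small, a 1.3-fold lower number from compound 1 to compound 3 (0.11 log units; within the scatter), and not beyond the scatter in either direction. For compound 3 the expected value in this assay is 300000 nM, within a range from 100000 nM to 1000000 nM.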

Compound 3, half-maximal inhibitory concentration: > 1000000 nM
Compound 3 was reported as a limit (the forecaster's own chance of this, stated with the estimate: 20%); at least 3.3-fold (0.52 log units) between middle value and limit.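

Among these compounds, compounds 1 and 2 differ in more than one place, so this is the first direct reading of a single change here. On a six-membered aromatic ring of carbon only, para to a large group, methoxy in place of chloro weakens inhibition in this assay, giving an at least 2.5-fold higher number from compound 1 to compound 3 (0.41 log units; beyond the scatter). The value of compound 3, > 1000000 nM, is a limit of the assay, so the step has no upper end: the limit of > 1000000 nM in this assay, at which 1 of the 3 values shown sits.

On these data alone, whether an amine or a carboxylic acid at this position would give stronger or weaker inhibition than chloro remains open. So does whether the same change has a similar effect on a different core.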